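From 4-cyanophenyl to 2,4-difluorophenyl in compound 3

The source may report more compounds than this note shows. Statements on the series, on what has been measured and on what is new or still open speak of the compounds shown alone.

Values in a functional assay on MDA-MB-436 cells (Homo sapiens) for antiproliferative activity, read by MTT assay, with a stated time of 48 h (a higher number here means a weaker inhibitor, a lower number a stronger inhibitor), are:
- compound 1 `CCS(=O)(=O)N1CCN(c2ncnc3sc(-c4ccc(N5CCN(C)CC5)cc4)cc23)CC1` gives 10600 nM
- compound 2 `CN1CCN(c2ccc(-c3cc4c(N5CCN(S(=O)(=O)N6CCCCC6)CC5)ncnc4s3)cc2)CC1` gives 7570 nM
- compound 3 `CN1CCN(c2ccc(-c3cc4c(N5CCN(C(=O)Nc6ccc(C#N)cc6)CC5)ncnc4s3)cc2)CC1` gives 5010 nM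

Compound 3 sits within the scatter of compound 2 and modestly under compound 1 alone. Compound 4 `CN1CCN(c2ccc(-c3cc4c(N5CCN(C(=O)Nc6ccc(F)cc6F)CC5)ncnc4s3)cc2)CC1` has 2,4-difluorophenyl in place of 4-cyanophenyl on an amide-type nitrogen. Two measured steps replace the whole group on an amine nitrogen in a ring, and they show a 2.1-fold lower number from compound 1 to compound 3 (0.33 log units; beyond the scatter) and a 1.5-fold lower number from compound 2 to compound 3 (0.18 log units; within the scatter) without isolating this smaller swap. Among the measured compounds shown here, no measured step changes only the group on the amide-type nitrogen. In this assay the expected result is a 1.0-fold lower number from compound 3 to compound 4 (0.00 log units; within the scatter) with no shift beyond the scatter in either direction. Compound 4 is estimated at 5000 nM (expected range 2000 nM to 12000 nM).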

Compound 4, half-maximal inhibitory concentration: 20200 nM
The estimate for compound 4 lay 4.0-fold (0.61 log units) below the measured number; measured number outside the range, above it.
By their numbers in this assay, from the lowest: compounds 3, 2, 1 and 4 (each within the scatter of the next, the first and the last beyond it).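

In this assay the group on the amide-type nitrogen proves to matter: with the rest of the molecule unchanged, 2,4-difluorophenyl in place of 4-cyanophenyl gives a 4.0-fold higher number from compound 3 to compound 4 (0.61 log units; beyond the scatter) in this series. The carbamoyl link alone therefore does not fix the number: the (2,4-difluorophenyl)carbamoyl group gives a 2.7-fold higher number from compound 2 to compound 4 (0.43 log units; beyond the scatter) and also a 1.9-fold higher number from compound 1 to compound 4 (0.28 log units; within the scatter) when it replaces a sulfonyl group. Nothing available explains why this swap has the effect it does.

The swap removes the nitrile and brings in two fluorines at once, so the compounds shown cannot say which part carries the step. Plain phenyl or 4-fluorophenyl on the same nitrogen would help separate the two.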